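The compounds below may be only part of what the source reports. "The series", "measured", "known", "first", "only" and "open" are said of these compounds alone.

Measured compounds in the series:

- compound 1, `Cc1ccc(-n2nc(C(F)(F)F)cc2CNC(=O)Nc2cccc3[nH]ncc23)cc1C`: in an assay on CHO-K1 cells for antagonist activity at transient receptor potential cation channel subfamily V member 1 (Homo sapiens), read by FLIPR and calcium flux, with a stated time of 6 min (on this read-out lower numbers stand for stronger inhibition and higher numbers for weaker inhibition), compound 1 gives 2.8 nM
- compound 2, `Cn1ncc2c(NC(=O)NCc3cc(C(F)(F)F)nn3-c3ccc(Cl)cc3)cccc21`: compound 2 gives 2.7 nM
- compound 3, `Cn1ncc2c(NC(=O)NCc3cc(C(F)(F)F)nn3-c3ccc(F)cc3)cccc21`: compound 3 gives 8.4 nM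

Compound 3 stands highest of the three numbers in this assay; compound 1 and compound 2 both sit lower, each beyond the scatter from compound 3. For the measured compounds named here, the one single-point step recorded is a 3.1-fold higher number from compound 2 to compound 3 (0.49 log units; beyond the scatter), a modest worsening.

Compound 4, `Cc1ccc(-n2nc(C(F)(F)F)cc2CNC(=O)Nc2cccc3c2cnn3C)cc1C`, is compound 3 with 3,4-dimethylphenyl in place of 4-fluorophenyl on an aromatic nitrogen. Going by the values given here, no measured step isolates this exchange: compound 1 carries the same 3,4-dimethylphenyl group but differs from compound 3 in a second place, so its value only shows that a 3,4-dimethylphenyl compound can reach the low numbers in this assay. The step of a 3.1-fold higher number from compound 2 to compound 3 (0.49 log units; beyond the scatter) shows that the group on this aromatic nitrogen moves the number by a modest amount, with 4-fluorophenyl the weaker of the two tested. A modest step downward is therefore expected, a 2.6-fold lower number from compound 3 to compound 4 (0.42 log units; beyond the scatter), as the 4-fluorophenyl leaves. Compound 4 is estimated at 3.2 nM, range 1.2 nM to 9 nM.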

Compound 4, inhibition constant: 3.5 nM
Beside the measured number, compound 4's estimate is 1.1-fold (0.04 log units) below it, within the range that was stated.
By their numbers in this assay, from the lowest: compounds 2, 1 and 4 (each within the scatter of the next); then compound 3.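

In this assay, a third substituted phenyl can now be compared on the aromatic nitrogen of the five-membered ring: a 2.4-fold lower number from compound 3 to compound 4 (0.38 log units; beyond the scatter) is a modest step beyond the scatter, with the 4-fluorophenyl compound standing apart from the 3,4-dimethylphenyl compound. Against the 4-chlorophenyl compound, a 1.3-fold higher number from compound 2 to compound 4 (0.11 log units; within the scatter) lies within the scatter, so 3,4-dimethylphenyl and 4-chlorophenyl cannot be told apart at this position. The nitrogen of the core also gets its first isolated reading: a 1.3-fold higher number from compound 1 to compound 4 (0.10 log units; within the scatter) for methyl in place of hydrogen is within the scatter, so this pair shows no readable change.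

Still open, from the compounds shown here alone, is how a phenyl bearing an amine or a carboxylic acid would read on the five-membered ring, or a longer chain on the core nitrogen. No measurement at hand gives a reason for any of these steps.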